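The compounds below may be only part of what the source reports. "The series", "measured", "known", "first", "only" and "open" are said of these compounds alone.

Compound 2, with the structure `COc1ccc(/C=C/C(=O)c2ccc(NC(=O)CO[N+](=O)[O-])cc2)cc1`, gives 33% in a functional assay on the whole organism (strain albino) for inhibition, with Rattus norvegicus as the target, read by paw edema, with stated times of 30 min and 1 h, at a dose of 100 mg/kg by the oral route; a higher number here means more inhibition at the dose given (going by the name of the read-out), a lower number less inhibition. Among the three measured compounds it has the lowest number, yet its nearest neighbour, compound 3, with the structure `O=C(CO[N+](=O)[O-])Nc1ccc(C(=O)/C=C/c2ccco2)cc1`, gives 34%, and the step of a number 1 percentage points higher from compound 2 to compound 3 (within the scatter) is within the scatter. Compound 1, with the structure `O=C(CO[N+](=O)[O-])Nc1ccc(C(=O)/C=C/c2ccc(Cl)cc2)cc1`, gives 42%, and the step of a number 9 percentage points lower from compound 1 to compound 2 (within the scatter) is within the scatter as well, so the three cannot be told apart on these numbers.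

Compound 4, with the structure `COc1ccc(/C=C/C(=O)c2ccc(NC(=O)COc3ccc(/C(C)=N\O)cc3)cc2)cc1`, has not been measured. It differs from compound 2 in one place: a group of 10 heavy atoms (8 carbon, 1 nitrogen, 1 oxygen; one six-membered aromatic ring of carbon only) in place of a group of 3 heavy atoms (1 nitrogen, 2 oxygen; no ring), on an oxygen on a saturated carbon.

Within the data shown here, no measured step bears directly on this change. The steps seen so far, a number 9 percentage points lower from compound 1 to compound 2 (within the scatter), a number 8 percentage points lower from compound 1 to compound 3 (within the scatter) and a number 1 percentage points higher from compound 2 to compound 3 (within the scatter), all replace the ring on a double-bonded chain carbon and all stay within the scatter; none touches the oxygen on the saturated carbon where the nitro leaves. Among the measured compounds shown here, the only guide is that every change tried so far has left this assay unmoved, so the expected step is no change at the digits printed from compound 2 to compound 4 (within the scatter), nothing beyond the scatter, though with little certainty. Compound 4 is therefore estimated to give 33%, within a range from 18% to 50%.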

Compound 4, a percentage reported as inhibition, in the whole organism at one dose (the size of the read-out at that dose, not a potency): 33%
Beside the measured number, compound 4's estimate shows no gap at the digits printed; the range from low to high includes it.
By their numbers in this assay, from the lowest: compounds 2, 4, 3 and 1 (each within the scatter of the next).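

Among these compounds, until now only the ring on the double-bonded chain carbon had been varied, and compound 4 is the first change on an oxygen on a saturated carbon, where the nitro leaves. In this assay the exchange gives no change at the digits printed from compound 2 to compound 4 (within the scatter), so in this pair, at this one dose, losing the nitro and adding a much larger group with a six-membered aromatic ring does not shift the read-out beyond the scatter. No supporting data offer an account of why the two compounds read alike.

From the compounds shown here alone, whether a small group such as a methyl or a longer alkyl chain on this oxygen would read the same remains open. So does whether the exchange holds when the 4-methoxyphenyl of compound 2 is replaced by the 4-chlorophenyl of compound 1 or the furan-2-yl of compound 3.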